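Ring Closure on the Amide Side Chain: Compound 3

The source may hold more compounds than are shown below. What is called first, only, known or untested is meant among the compounds shown, and "the series" means these compounds.

Compound 2 `COc1ccc(-c2csc(NC(=O)CN(C)C)n2)cc1` gives 35% in a functional assay on the whole organism (strain AKR) for inhibition, with Rattus norvegicus as the target, read by paw edema, at a dose of 0.2 mmol/kg by the intraperitoneal route, in the presence of a further agent that is not named here (on this read-out lower numbers stand for less inhibition and higher numbers for more inhibition at the one dose given (going by the name of the read-out)), the lower of the two values shown, while compound 1 `COc1ccc(-c2csc(NC(=O)CCN3CCCC3)n2)cc1` gives 56.2%. Compound 3 `COc1ccc(-c2csc(NC(=O)CN3CCCC3)n2)cc1` differs from compound 2 by pyrrolidin-1-yl in place of dimethylamino on a saturated chain carbon bound to a carbonyl carbon. Within the data shown here, one measured step bears on this change: a number 21.2 percentage points lower from compound 1 to compound 2 (beyond the scatter). Compound 3 brings the five-membered ring back while keeping the shorter chain, so only part of that loss is expected to return. For compound 3 the estimated step is a number 12 percentage points higher from compound 2 to compound 3 (beyond the scatter), a rise beyond the scatter. Compound 3 is therefore expected near 47%, within 30% to 64%.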

Compound 3, a percentage reported as inhibition, in the whole organism at one dose (the size of the read-out at that dose, not a potency): 55%
Beside the measured number, compound 3's estimate is 8 percentage points below it, and the stated range covers the measured number.
By their numbers in this assay, from the lowest: compound 2; then compounds 3 and 1 (each within the scatter of the next).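

Going from dimethylamino to pyrrolidin-1-yl on a saturated chain carbon bound to a carbonyl carbon gives a number 20 percentage points higher from compound 2 to compound 3 (beyond the scatter) in this assay, so the ring alone carries a real gain at this position. Pyrrolidin-1-yl in place of (pyrrolidin-1-yl)methyl gives a number 1.2 percentage points lower from compound 1 to compound 3 (within the scatter) in the same test, so the lower reading of compound 2 goes with the open dimethylamino group and not with the shorter chain.

On these data alone, whether a piperidin-1-yl or morpholin-4-yl group would read as well as pyrrolidin-1-yl stays open. Nothing measured here explains why the ring form reads higher.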